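Adding One Carbon to Compound 1: Expected Cytotoxicity

The compounds below may be only part of what the source reports. "The series", "measured", "known", "first", "only" and "open" are said of these compounds alone.

Compound 1 `C/C(=N\NC(=O)c1cccc2ccccc12)c1ccccc1O` is one of a small set of related compounds that share one core and differ in the group attached to the carbonyl carbon. In a toxicity assay (H9c2 cells) for cytotoxicity, with Rattus norvegicus as the target, read by neutral red uptake, with a stated time of 72 h (on this read-out lower numbers stand for stronger inhibition and higher numbers for weaker inhibition), compound 1 gives > 200000 nM. That reading is a limit of the measurement and not a number, and it is the limit of > 200000 nM in this assay, at which 1 of the 3 values shown sits. Compound 2 `C/C(=N\NC(=O)c1ccnnc1)c1ccccc1O` gives 22800 nM in this assay, and compound 3 `C/C(=N\NC(=O)c1cccnc1)c1ccccc1O` gives 6800 nM. Within the data shown here, the single measured step, a 3.4-fold lower number from compound 2 to compound 3 (0.53 log units; beyond the scatter), concerns the group on the carbonyl carbon.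

Compound 4 `CC/C(=N\NC(=O)c1cccc2ccccc12)c1ccccc1O` differs from compound 1 by methyl in place of hydrogen on a saturated chain carbon bound to a carbon with a double bond to nitrogen. Among the measured compounds shown here, no measured step alters this part of the molecule, so the step from the two pyridine-type compounds does not bear on it. Compound 4 is therefore expected to remain at or near the limit, with an estimated value of 250000 nM, in a range from 60000 nM to 1000000 nM. Compound 4 is expected to show a step that the limit leaves unreadable from compound 1 to compound 4, no change beyond the scatter.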

Compound 4, half-maximal inhibitory concentration: > 200000 nM
Compound 4 was reported as a limit (the forecaster's own chance of this, stated with the estimate: 75%); the middle value does not contradict the limit.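

In this assay compound 4 and compound 1 are both reported only as limits, so no step can be read between the two: the limit of > 200000 nM in this assay, at which 2 of the 4 values shown sit.

The compounds shown leave open whether methyl in place of hydrogen at this place changes the reading at all.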